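Swapping Methyl for 3,5-Dimethylphenyl in Compound 1

The source may report more compounds than this note shows. Statements on the series, on what has been measured and on what is new or still open speak of the compounds shown alone.

In a functional assay on Jurkat cells (Homo sapiens) for antiproliferative activity, read by MTT assay, with a stated time of 48 h (on this read-out higher numbers stand for weaker inhibition and lower numbers for stronger inhibition), compound 1 `CCN1C(=O)C(=O)c2cc(/C=C/C(=O)OC)ccc21` gives 200 nM. For the measured compounds named here, that is the lower of the two numbers available so far, and so the stronger inhibition: compound 2 `COC(=O)/C=C/c1ccc2c(c1)C(=O)C(=O)N2Cc1ccc2ccccc2c1` reads 640 nM, and the gap between them lies beyond the usual scatter of repeated measurements. Still unmeasured is compound 3 `COC(=O)/C=C/c1ccc2c(c1)C(=O)C(=O)N2Cc1cc(C)cc(C)c1`, which shares the core of compound 1. It differs in one place, on a saturated chain carbon bound to an amide-type nitrogen in a ring, where 3,5-dimethylphenyl stands in place of methyl: 3,5-dimethylphenyl in place of methyl on a saturated chain carbon bound to an amide-type nitrogen in a ring. Going by the values given here, no measured pair shows a change of this kind, so any expectation is loose. Among the compounds with values here, the only guide is compound 2 at 640 nM, whose number is higher than that of compound 1. In this assay a modest step toward a higher number, meaning weaker inhibition, is therefore expected, and it may well stay within the scatter. The estimated step is a 1.5-fold higher number from compound 1 to compound 3 (0.18 log units; within the scatter). For compound 3 the estimated value is 300 nM, with an expected range of 90 nM to 1000 nM.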

Compound 3, half-maximal inhibitory concentration: 620 nM
Beside the measured number, compound 3's estimate is 2.1-fold (0.32 log units) below it, and the stated range covers the measured number.
By their numbers in this assay, from the lowest: compound 1; then compounds 3 and 2 (each within the scatter of the next).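

In this assay, the saturated chain carbon bound to an amide-type nitrogen in a ring now proves sensitive to a single change: 3,5-dimethylphenyl in place of methyl gives a 3.1-fold higher number from compound 1 to compound 3 (0.49 log units; beyond the scatter). The added bulk of eight carbon atoms and one six-membered aromatic ring therefore comes with weaker inhibition in this series, while the shared core stays the same, and compound 3 at 620 nM and compound 2 at 640 nM lie within the scatter of each other, so the two compounds cannot be ranked even though they carry different groups at this place. No measurement bears on why the number rises with this change.

The compounds shown leave open how a plain propyl or butyl chain, or a phenyl without its two methyl groups, would read at this place, and so whether the higher number already appears with a smaller group than 3,5-dimethylphenyl. They also leave open whether an amine or a carboxylic acid on this group would move the number in either direction.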